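Three Amides and a Sulfonyl Newcomer

This account rests on a few compounds, and the source may have more. Where it says the series, first, only, none or still open, it means among the compounds named here.

compound 1 `O=C(Nc1cccc(N2CCCC2=O)c1)C1CCCN(C(=O)c2cc(C(F)(F)F)cc(C(F)(F)F)c2)C1` gives 0% in an ADME assay on PC-3 cells (Homo sapiens) for cytotoxicity, read by WST assay, tested at 100 uM; a lower number here means less inhibition, a higher number more inhibition at the concentration tested (going by the name of the read-out)
compound 2 `CC(C)(C)OC(=O)c1cccc(NC(=O)C2CCCN(C(=O)c3cc(C(F)(F)F)cc(C(F)(F)F)c3)C2)c1` gives 0% in this assay
compound 3 `O=C(Nc1cccc(OCCc2ccccn2)c1)C1CCCN(C(=O)c2cc(C(F)(F)F)cc(C(F)(F)F)c2)C1` gives 5% in this assay

All three numbers sit near zero, so the inhibition in this assay is level across these compounds. Compound 3 carries the number that is nominally furthest from zero, but a number 5 percentage points higher from compound 1 to compound 3 (within the scatter) and a number 5 percentage points higher from compound 2 to compound 3 (within the scatter) both fall inside the usual scatter, so compound 3 is not really set apart from compound 1 or compound 2.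

Compound 4 `O=C(Nc1cccc(S(=O)(=O)N2CCCC2)c1)C1CCCN(C(=O)c2cc(C(F)(F)F)cc(C(F)(F)F)c2)C1` arises from compound 3 by the following change: (pyrrolidin-1-yl)sulfonyl in place of 2-(pyridin-2-yl)ethoxy on an aromatic carbon

Every measured step swaps a group at this same aromatic carbon, and none of them moved the read-out: no change at the digits printed from compound 1 to compound 2 (within the scatter), a number 5 percentage points higher from compound 1 to compound 3 (within the scatter) and a number 5 percentage points higher from compound 2 to compound 3 (within the scatter) all stay within the scatter. Nothing indicates that a (pyrrolidin-1-yl)sulfonyl group would behave differently, so no step beyond the scatter is expected, a number 2 percentage points lower from compound 3 to compound 4 (within the scatter). Compound 4 is therefore estimated at 3% in this assay, within 0% to 15%.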

Compound 4, a percentage reported as inhibition, at one concentration (the size of the read-out at that concentration, not a potency): 0%
Compound 4: middle estimate off by 3 percentage points, on the high side; the measured number falls inside the stated range.
By their numbers in this assay, from the lowest: compounds 1, 2, 4 and 3 (each within the scatter of the next).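

Among these compounds, compound 4 brings a sulfonyl group with a saturated five-membered ring to this aromatic carbon, a type of substituent the earlier compounds do not carry, yet the read-out in this assay still cannot separate it from the others. The steps are a number 5 percentage points lower from compound 3 to compound 4 (within the scatter) and no change at the digits printed from compound 2 to compound 4 (within the scatter) and also no change at the digits printed from compound 1 to compound 4 (within the scatter) and so four different groups at this one carbon now give numbers that cannot be told apart. Nothing available here explains why these numbers stay so close to zero.

The compounds shown leave open whether a group of another kind at this carbon, such as a primary amine or a carboxylic acid, would give a number beyond the scatter. They also leave open whether a change elsewhere on the shared core would do so.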